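The source may hold more compounds than are shown below. What is called first, only, known or untested is meant among the compounds shown, and "the series" means these compounds.

Three compounds share one core and differ only in the group on the aromatic nitrogen. In an assay on isolated protein for inhibition of Gonadotropin-releasing hormone receptor (Homo sapiens) (on this read-out lower numbers stand for stronger inhibition and higher numbers for weaker inhibition), compound 1 `CCn1c(SCc2cc([N+](=O)[O-])ccc2OC)nc2cc(NC(=O)NC(C)(C)C)ccc21` gives 42 nM, compound 2 `CCCn1c(SCc2cc([N+](=O)[O-])ccc2OC)nc2cc(NC(=O)NC(C)(C)C)ccc21` gives 18 nM, and compound 3 `COc1ccc([N+](=O)[O-])cc1CSc1nc2cc(NC(=O)NC(C)(C)C)ccc2n1Cc1cccnc1` gives 33 nM. Compound 2 stands lowest of the three numbers, though only a 2.3-fold lower number from compound 1 to compound 2 (0.37 log units; beyond the scatter) lies beyond the scatter, while a 1.8-fold higher number from compound 2 to compound 3 (0.26 log units; within the scatter) stays within it. Compound 4 `CCCn1c(SCc2cc([N+](=O)[O-])ccc2OC)nc2cc(NC(=O)NC(C)(C)C)cc(C(=O)NCc3ccccc3)c21` keeps compound 2 and adds (benzylcarbamoyl in place of hydrogen on an aromatic carbon). Among the compounds with values here, no measured step touches that aromatic carbon; all three steps concern the chain on the aromatic nitrogen, so they give no guidance on this change. The expected step is therefore no change at the digits printed from compound 2 to compound 4 (within the scatter), meaning none beyond the scatter. Compound 4 is estimated at 18 nM, within 5 nM to 70 nM.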

Compound 4, half-maximal inhibitory concentration: 120 nM
For compound 4 the middle estimate is 6.7-fold (0.82 log units) below the measured one; the whole stated range lies below it.
By their numbers in this assay, from the lowest: compounds 2, 3 and 1 (each within the scatter of the next, the first and the last beyond it); then compound 4.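

Within the data shown here, the aromatic carbon ortho to a fused ring, untouched by the earlier compounds, turns out to matter in this assay: benzylcarbamoyl in place of hydrogen gives a 6.7-fold higher number from compound 2 to compound 4 (0.82 log units; beyond the scatter), which means weaker inhibition. So the core does not accept this group here without a loss, even though the chain on the aromatic nitrogen had moved the numbers little. Nothing measured here accounts for the rise. Still open, from the compounds shown here alone, is whether a smaller group on this carbon, such as methyl or a carboxylic acid, would keep the number of compound 2.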